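Fluoro to methoxy on the benzhydryl ring

The compounds below may be only part of what the source reports. "The series", "measured", "known", "first", "only" and "open" are said of these compounds alone.

Measured so far:
compound 1, `O=C(O)Cc1sc(C(c2ccccc2)c2ccc(Cl)cc2)nc1-c1ccc(Cl)cc1`: 45 nM
compound 2, `O=C(O)Cc1sc(C(c2ccccc2)c2ccc(F)cc2)nc1-c1ccc(Cl)cc1`: 17 nM

Both compounds share one core and were tested in an in vitro assay on HEK385-7 cells for displacement of a labelled ligand from prostaglandin D2 receptor 2 (Homo sapiens); a lower number here means a stronger inhibitor, a higher number a weaker inhibitor. Within the data shown here, compound 2 gives the lowest number of the two; its nearest neighbour is compound 1, and the step of a 2.6-fold lower number from compound 1 to compound 2 (0.42 log units; beyond the scatter) is the only measured step, a modest one beyond the scatter, fluoro replacing chloro on an aromatic carbon.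

Compound 3, `COc1ccc(C(c2ccccc2)c2nc(-c3ccc(Cl)cc3)c(CC(=O)O)s2)cc1`, differs from compound 2 by methoxy in place of fluoro on an aromatic carbon, on an aromatic carbon of a six-membered aromatic ring of carbon only, para to a large group. Among the measured compounds shown here, the only step that bears on this position is a 2.6-fold lower number from compound 1 to compound 2 (0.42 log units; beyond the scatter); no methoxy analogue has been measured here, so the size of the change for compound 3 is uncertain. The expectation is a step of about a 2.9-fold higher number from compound 2 to compound 3 (0.47 log units; beyond the scatter), toward a higher number in this assay. The estimated value for compound 3 in this assay is 50 nM, within a range of 15 nM to 170 nM.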

Compound 3, half-maximal inhibitory concentration: 8.4 nM
Beside the measured number, compound 3's estimate is 6.0-fold (0.77 log units) above it, outside the stated range (below it).
By their numbers in this assay, from the lowest: compound 3; then compound 2; then compound 1.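

In this assay, among these compounds, the step of a 2.0-fold lower number from compound 2 to compound 3 (0.31 log units; beyond the scatter) shows that this position tolerates more than a halogen: methoxy, the first non-halogen group here, does not raise the number but lowers it further. With the step of a 5.4-fold lower number from compound 1 to compound 3 (0.73 log units; beyond the scatter), the largest in the series, compound 3 now lies beyond the scatter from both halogen analogues, and the order at this position runs methoxy, fluoro, chloro, from the lowest number to the highest. No measured property is available to account for this order.

Three groups at one position cannot show whether the gain belongs to methoxy specifically or extends to other groups. From the compounds shown here alone, a hydroxyl, an ethoxy or an amine at the same place would test this, and the effect of moving methoxy elsewhere on the ring remains open.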